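Working notes: from 2-hydroxyethyl to 1-(hydroxymethyl)propyl

This account rests on a few compounds, and the source may have more. Where it says the series, first, only, none or still open, it means among the compounds named here.

Measured in a functional assay on MCF7 cells (Homo sapiens) for inhibition, read by fluorescence, with a stated time of 72 h; on this read-out higher numbers stand for weaker inhibition and lower numbers for stronger inhibition:
- compound 1 `N=C(N)Nc1nc(N)nc2c1ncn2CCO` gives > 100000 nM, which is a limit of the assay
- compound 2 `CC(C)n1cnc2c(NC(=N)N)nc(NCCO)nc21` gives 12400 nM

Within the data shown here, compound 2 holds the only actual number so far, since the other value shown is a limit. Among the measured compounds shown here, no measured step between compounds differing in one place is available, so nothing yet shows how a change of this kind acts in this assay.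

Next is compound 3 `CC[C@H](CO)Nc1nc(NC(=N)N)c2ncn(C(C)C)c2n1`. Its difference from compound 2 is ethyl in place of hydrogen on a saturated chain carbon bound to a nitrogen on an aromatic ring and a saturated chain carbon. In other words, 2-hydroxyethyl becomes 1-(hydroxymethyl)propyl.

The expectation rests only on compound 2 at 12400 nM and on this single change, so it is held loosely. A small move toward stronger inhibition is expected, near the edge of the usual scatter. The expected step is a 2.1-fold lower number from compound 2 to compound 3 (0.32 log units; beyond the scatter). For compound 3 the estimated value is 6000 nM, with an expected range from 1800 nM to 20000 nM.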

Compound 3, half-maximal inhibitory concentration: 4500 nM
Compound 3: the middle estimate sits 1.3-fold (0.12 log units) above what was measured; the range from low to high includes it.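

In this assay the series now has its first readable step, a 2.8-fold lower number from compound 2 to compound 3 (0.44 log units; beyond the scatter), which is modest but beyond the usual scatter. It shows that, on a saturated chain carbon bound to a nitrogen on an aromatic ring and a saturated chain carbon, ethyl in place of hydrogen goes with stronger inhibition rather than a loss of it, so this position accepts 2 added carbon atoms in this assay. Nothing in the data shown bears on why the number moves.

As far as these compounds go, with a single step at this place, no trend with the size or shape of the group can be claimed, and whether methyl, a longer chain such as butyl, or a phenyl ring at the same carbon would extend, stop or reverse the move remains open. Among these compounds, compound 1 gives > 100000 nM, which is a limit of the assay, and it joins no step, so the series still rests on the one comparison.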